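The source may report more compounds than this note shows. Statements on the series, on what has been measured and on what is new or still open speak of the compounds shown alone.

Measured compounds in this series:
- compound 1, `Fc1ccc(Cn2cc(CSC(=S)N3CCNCC3)nn2)cc1`: in a functional assay on PC-3 cells (Homo sapiens) for inhibition, read by MTT assay, with a stated time of 72 h (on this read-out lower numbers stand for stronger inhibition and higher numbers for weaker inhibition), compound 1 gives > 128000 nM, which is a limit of the assay and not a number.
- compound 2, `O=C(OCc1ccccc1)N1CCN(C(=S)SCc2cn(Cc3ccc(Cl)cc3)nn2)CC1`: compound 2 gives > 128000 nM, again a limit.
- compound 3, `CC(C)(C)OC(=O)N1CCN(C(=S)SCc2cn(Cc3cc(=O)oc4cc(O)ccc34)nn2)CC1`: compound 3 gives 36800 nM.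

Compound 2 stands with no number of its own in this assay: only a limit is reported for it, and it shares that limit with one other compound, as the limit of > 128000 nM in this assay, at which 2 of the 3 values shown sit, records. Within the data shown here, compound 3 is the only compound of the three with a numerical value, and no step between measured compounds that differ in one place is available, so no measured size of change can be drawn on.

Compound 4, `Cc1ccc(Cn2cc(CSC(=S)N3CCN(C(=O)OCc4ccccc4)CC3)nn2)cc1`, is the untested analogue. The change from compound 2 reads methyl in place of chloro on an aromatic carbon, para to a large group.

With compound 2 sitting at a limit, no step beyond the usual scatter is expected in this assay; compound 4 is expected to give about 128000 nM, within 40000 nM to 300000 nM. That estimate means a step of a number no higher from compound 2 to compound 4 (the limit leaves the size open), and most likely the assay would again report only a limit.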

Compound 4, half-maximal inhibitory concentration: > 128000 nM
Compound 4: a limit, no number; the forecaster's own chance of this, stated with the estimate: 80%; the middle value sits exactly at the limit.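

The step from compound 2 to compound 4, methyl in place of chloro on an aromatic carbon, cannot be read, as both compounds give only a limit in this assay: the limit of > 128000 nM in this assay, at which 3 of the 4 values shown sit.

The compounds shown leave open whether 4-chlorobenzyl and 4-methylbenzyl differ at all in this assay.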